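The source may hold more compounds than are shown below. What is called first, only, known or untested is meant among the compounds shown, and "the series" means these compounds.

Compound 1 `COc1cc(-c2cc(/C=C/C(=O)c3ccc(Cl)c(Cl)c3)[nH]n2)cc(OC)c1OC` and compound 2 `COc1ccc(-c2cc(/C=C/C(=O)c3ccc(N)cc3)[nH]n2)cc1` were both tested in a functional assay on SF-539 cells (Homo sapiens) for cytotoxicity, read by sulforhodamine B assay, with a stated time of 48 h, tested at 0.1 uM; on this read-out higher numbers stand for a weaker effect at the one concentration tested and lower numbers for a stronger effect. In this assay compound 1 gives 94%, the smaller of the two numbers shown, though the gap to compound 2, which gives 97%, lies within the usual scatter, so nothing separates them. Compound 3 `COc1cc(-c2cc(/C=C/C(=O)c3ccc(F)c(F)c3)[nH]n2)cc(OC)c1OC` has not been measured in this assay. It differs from compound 1 in one place: 3,4-difluorophenyl in place of 3,4-dichlorophenyl on a carbonyl carbon. Among the compounds with values here, no measured pair shows what this change does, so the size of the step can only be expected, not read off. The expected step, a number 2 percentage points higher from compound 1 to compound 3 (within the scatter), is small and, if anything, toward a slightly higher number, not beyond the scatter. Because compound 1 gives 94% in this assay, compound 3 is expected to sit close by, estimated at 96% with a range from 85% to 105%.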

Compound 3, a percentage reported as activity, at one concentration (the size of the read-out at that concentration, not a potency): 97%
The estimate for compound 3 lay 1 percentage points below the measured number, and the stated range covers the measured number.
By their numbers in this assay, from the lowest: compounds 1, 2 and 3 (each within the scatter of the next).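

Within the data shown here, the first measured step at this position comes from exchanging 3,4-dichlorophenyl for 3,4-difluorophenyl on the carbonyl carbon. In this assay this exchange gives a number 3 percentage points higher from compound 1 to compound 3 (within the scatter), so the two halogen pairs cannot be told apart on this read-out at the one concentration tested. No measurement at hand speaks to why the exchange leaves the read-out where it is.

From the compounds shown here alone, it remains open whether a different kind of group on the carbonyl carbon, such as a pyridine ring or a phenyl ring bearing a carboxylic acid or a morpholine, would separate from compound 1 by more than the scatter. A single concentration also leaves open whether the halogen exchange would matter at other concentrations.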